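Swapping a Large Sulfur Group for Chloro

The compounds below may be only part of what the source reports. "The series", "measured", "known", "first", "only" and "open" are said of these compounds alone.

Values so far in a functional assay on HCT-116 cells (Homo sapiens) for cytotoxicity, read by MTT assay, with a stated time of 72 h; on this read-out higher numbers stand for weaker inhibition and lower numbers for stronger inhibition

Compound 1 `C=C1C2=C(C(=O)N1OC)[C@H](OC(=O)CSc1nc3ccccc3o1)[C@@](C)(O)[C@H](CCCCC)O2` gives 4900 nM
Compound 2 `C=C1C2=C(C(=O)N1OC)[C@H](OC(=O)CSc1nc3ccccc3[nH]1)[C@@](C)(O)[C@H](CCCCC)O2` gives 8200 nM

The two measured compounds cannot be told apart on these numbers. The step between them is a 1.7-fold higher number from compound 1 to compound 2 (0.22 log units; within the scatter), so compound 2 sits level with compound 1.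

Compound 3 `C=C1C2=C(C(=O)N1OC)[C@H](OC(=O)CCl)[C@@](C)(O)[C@H](CCCCC)O2` keeps the shared core but changes one end of the molecule: chloro in place of (1H-benzimidazol-2-yl)sulfanyl on a saturated chain carbon bound to a carbonyl carbon.

Among the compounds with values here, only one measured step bears on this change. It exchanged 1,3-benzoxazol-2-yl for 1H-benzimidazol-2-yl on a sulfur and came to a 1.7-fold higher number from compound 1 to compound 2 (0.22 log units; within the scatter). That step kept the sulfur and a two-ring group in place, whereas here both leave, so it offers only weak guidance. Within the data shown here, no measured compound shows the effect of losing the whole group. In this assay, among the measured compounds shown here, a slight lean toward a lower number is expected, but no step clearly beyond the scatter, and the uncertainty is wide. The expected step is a 1.8-fold lower number from compound 2 to compound 3 (0.26 log units; within the scatter). Compound 3 is estimated at 4500 nM, with an expected range from 1200 nM to 16000 nM.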

Compound 3, half-maximal inhibitory concentration: 2400 nM
Beside the measured number, compound 3's estimate is 1.9-fold (0.27 log units) above it, within the range that was stated.
By their numbers in this assay, from the lowest: compound 3; then compounds 1 and 2 (each within the scatter of the next).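

In this assay, the large sulfur-bearing group is not required for activity at this position: exchanging it for chloro gives a 3.4-fold lower number from compound 2 to compound 3 (0.53 log units; beyond the scatter) and, starting from the benzoxazole-bearing partner, gives a 2.0-fold lower number from compound 1 to compound 3 (0.31 log units; beyond the scatter) as well. The earlier step only swapped one two-ring group for another and could not be read beyond the scatter, whereas these two steps, both modest but beyond it, show that a single chloro on a saturated chain carbon bound to a carbonyl carbon does better than either large group and make compound 3 the strongest of the three in this series. No measurement shown here explains why the number falls with this exchange.

From the compounds shown here alone, what remains open is whether the gain comes from chloro itself or simply from the loss of the large group, a question that a bromo, a methoxy, an amine or a plain hydrogen at this place could help to answer. A sulfur carrying only a small group such as methyl would also show whether the sulfur can stay while the two rings go.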